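A few compounds are considered here, and "the series" means these few. Any claim that something is new, unique, unknown or untested is made for them only; others in the source may bear on it.

Compound 1 `COc1ccc(CN(C(=O)CSC(=S)N2CCN(C(=O)OC(C)(C)C)CC2)c2cc(OC)c(OC)c(OC)c2)cc1`: 250 nM
Compound 2 `COc1ccc(CN(C(=O)CSC(=S)N2CCN(C(=O)OC(C)(C)C)CC2)c2ccc(Cl)cc2)cc1`: > 20000 nM, a limit
Compound 3 `COc1ccc(CN(C(=O)CSC(=S)N2CCN(C(=O)OC(C)(C)C)CC2)c2ccc(C)cc2)cc1`: > 20000 nM, a limit

In a functional assay on KYSE-450 cells (Homo sapiens) for inhibition, read by CCK-8 assay, with a stated time of 48 h (on this read-out lower numbers stand for stronger inhibition and higher numbers for weaker inhibition), compound 3 stands at > 20000 nM, which is a limit and not a number; this is the limit of > 20000 nM in this assay, at which 2 of the 3 values shown sit. Compound 4 `COc1ccc(CN(C(=O)CSC(=S)N2CCN(C(=O)OC(C)(C)C)CC2)c2ccc(OC)cc2)cc1` has methoxy in place of methyl on an aromatic carbon. Among the measured compounds shown here, two measured steps bear on this, both large: an at least 80-fold higher number from compound 1 to compound 2 (1.90 log units; beyond the scatter) and an at least 80-fold higher number from compound 1 to compound 3 (1.90 log units; beyond the scatter). The step that the two limits leave unreadable from compound 2 to compound 3 tells nothing. Only compound 1, with its 3,4,5-trimethoxyphenyl group, gives a number, 250 nM. Compound 4 keeps a single methoxy, so a smaller move toward lower numbers is expected, and it may stay at the limit. The expected step is an at least 3.3-fold lower number from compound 3 to compound 4 (0.52 log units; beyond the scatter). For compound 4 the estimated value is 6000 nM, with an expected range of 1500 nM to 20000 nM.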

Compound 4, half-maximal inhibitory concentration: > 20000 nM
Compound 4: no number, only a limit; the forecaster's own chance of this, stated with the estimate: 45%; at least 3.3-fold (0.52 log units) between middle value and limit.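

In this assay compound 4 also ends at a limit and not a number: the limit of > 20000 nM in this assay, at which 3 of the 4 values shown sit.

With a methoxy now on the ring, the change to 4-methoxyphenyl still gives an at least 80-fold higher number from compound 1 to compound 4 (1.90 log units; beyond the scatter), so a single methoxy group does not replace the 3,4,5-trimethoxyphenyl group. The steps among compound 2, compound 3 and compound 4 cannot be read, since each has only a limit.

Still open, from the compounds shown here alone, is whether a dimethoxyphenyl group would bring back a measurable value. The same holds for an amine or a hydroxy group on this aromatic carbon.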